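Swapping the Amide Substituent Before a New Measurement

A few compounds are considered here, and "the series" means these few. Any claim that something is new, unique, unknown or untested is made for them only; others in the source may bear on it.

All numbers here come from a functional assay on PC-3 cells (Homo sapiens) for cytotoxicity, read by sulforhodamine B assay, with a stated time of 48 h; a lower number here means a stronger inhibitor of growth, a higher number a weaker inhibitor of growth. Of the compounds shown here, two have been measured, and both share one core. Compound 1, `O=C(COc1ccc(/C=C2\SC(=O)NC2=O)cc1)Nc1cccc(C(F)(F)F)c1`, carries a trifluoromethyl-substituted phenyl group on an amide-type nitrogen. In this assay compound 1 gives < 100000 nM, which is a limit of the assay rather than a number. Compound 2, `O=C(COc1ccc(/C=C2\SC(=O)NC2=O)cc1)Nc1nc2ccccc2s1`, carries a 1,3-benzothiazol-2-yl group on the amide-type nitrogen. In this assay compound 2 gives < 100000 nM, again a limit of the assay and not a number. Compound 2 therefore stands at the limit, and this is true of everything shown so far (the limit of < 100000 nM in this assay, at which 2 of the 2 values shown sit). Compound 3, `O=C(COc1ccc(/C=C2\SC(=O)NC2=O)cc1)Nc1ncc([N+](=O)[O-])s1`, has not yet been measured; it differs from compound 2 in one place: 5-nitro-1,3-thiazol-2-yl in place of 1,3-benzothiazol-2-yl on an amide-type nitrogen. Among the compounds with values here, no step between measured compounds exists to guide the expectation, so the size of the change is judged from the structure alone. The expected step is modest and close to the scatter, amounting to a step that the limit leaves unreadable from compound 2 to compound 3. Compound 3 is expected to give about 20000 nM in this assay, between 3000 nM and 100000 nM.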

Compound 3, concentration for total growth inhibition: < 100000 nM
Compound 3 ended at the assay's limit; the forecaster's own chance of this, stated with the estimate: 55%; the middle value does not contradict the limit.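

Compound 2 and compound 3 both end at a limit rather than at a number, so no step can be read between them: the limit of < 100000 nM in this assay, at which 3 of the 3 values shown sit.

The compounds shown leave open whether 5-nitro-1,3-thiazol-2-yl in place of 1,3-benzothiazol-2-yl on an amide-type nitrogen changes growth inhibition at all, and in which direction.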